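Swapping Methoxy for Chloro on the Distal Aryl Ring

A few compounds are considered here, and "the series" means these few. Any claim that something is new, unique, unknown or untested is made for them only; others in the source may bear on it.

Measured compounds:
compound 1, `COc1ccc(N2CCN(CC(=O)N3CCN(c4nnc(-c5ccccc5)c(-c5ccccc5)n4)CC3)CC2)cc1`: > 910000 nM
compound 2, `O=C(CN1CCN(c2ccc(Cl)cc2)CC1)N1CCN(c2nnc(-c3ccccc3)c(-c3ccccc3)n2)CC1`: 113000 nM
compound 3, `COc1ccc(-c2nnc(N3CCN(C(=O)CN4CCN(c5cccc(OC)c5)CC4)CC3)nc2-c2ccc(OC)cc2)cc1`: > 821000 nM

In an ADME assay on NIH3T3 cells (Mus musculus) for cytotoxicity, read by MTT assay, with a stated time of 24 h (on this read-out lower numbers stand for stronger inhibition and higher numbers for weaker inhibition), compound 1 reaches only a limit of the assay, (the limit of > 910000 nM in this assay, at which 1 of the 3 values shown sits). Compound 3 likewise reaches only a limit, (the limit of > 821000 nM in this assay, at which 1 of the 3 values shown sits). From compound 1 to compound 2 the change is chloro in place of methoxy on an aromatic carbon, and it gave an at least 8.0-fold lower number from compound 1 to compound 2 (0.90 log units; beyond the scatter). Compound 4, `COc1ccc(-c2nnc(N3CCN(C(=O)CN4CCN(c5cccc(Cl)c5)CC4)CC3)nc2-c2ccc(OC)cc2)cc1`, is made from compound 3 by chloro in place of methoxy on an aromatic carbon. This is the same kind of change, though the place differs: para to a large group in the first pair, meta to a large group here. How the core of compound 1 and the core of compound 3 differ is not broken down here. Because the earlier pair showed an at least 8.0-fold lower number from compound 1 to compound 2 (0.90 log units; beyond the scatter), a similar drop in this assay is expected for compound 4. Compound 4 is therefore estimated at 200000 nM, an expected step of an at least 4.1-fold lower number from compound 3 to compound 4 (0.61 log units; beyond the scatter).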

Compound 4, half-maximal inhibitory concentration: > 814000 nM
Compound 4 ended at the assay's limit; the forecaster's own chance of this, stated with the estimate: 30%; middle value at least 4.0-fold (0.60 log units) away from the limit.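

Compound 3 and compound 4 each reach only a limit in this assay, and the step between them cannot be read. From the compounds shown here alone, whether chloro in place of methoxy lowers the number on the core of compound 3 stays open.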